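From Carboxy to Ethoxycarbonyl on a Shared Core

The compounds below may be only part of what the source reports. "The series", "measured", "known", "first", "only" and "open" are said of these compounds alone.

Of the compounds shown here, two have been measured in an assay on RBL-1 cells with Polyunsaturated fatty acid 5-lipoxygenase (Rattus norvegicus) as the target; on this read-out lower numbers stand for stronger inhibition and higher numbers for weaker inhibition. Compound 1 `CC(=O)c1cc(Cc2ccccc2)c(O)c2ccccc12` gives 510 nM. Compound 2 `O=C(O)c1cc(Cc2ccccc2)c(O)c2ccccc12` gives 5800 nM. For the measured compounds named here, the only step between them, an 11-fold higher number from compound 1 to compound 2 (1.06 log units; beyond the scatter), is a change of hydroxy in place of methyl on a carbonyl carbon, so compound 2 stands at the highest of the two numbers, with compound 1 as its only neighbour.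

Compound 3 `CCOC(=O)c1cc(Cc2ccccc2)c(O)c2ccccc12` differs from compound 2 by ethyl in place of hydrogen on an oxygen next to a carbonyl group. Going by the values given here, no measured step covers exactly this change. Among the compounds with values here, the one step that bears on it, the step from compound 1 to compound 2, shows that the group on the carbonyl carbon can move this assay by a large amount; the present change replaces the hydrogen of the hydroxy with ethyl, and it is expected to carry compound 3 part of the way back toward the number of compound 1. The expected step is a 3.9-fold lower number from compound 2 to compound 3 (0.59 log units; beyond the scatter). Compound 3 is therefore estimated at 1500 nM, with a range from 400 nM to 6000 nM.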

Compound 3, half-maximal inhibitory concentration: 160 nM
Compound 3: middle estimate off by 9.4-fold (0.97 log units), on the high side, and the stated range ends above it.
By their numbers in this assay, from the lowest: compound 3; then compound 1; then compound 2.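

With the third group on this carbonyl carbon, the picture in this assay changes: the earlier pair showed only that hydroxy in place of methyl raised the number, whereas hydroxy to ethoxy gives a 36-fold lower number from compound 2 to compound 3 (1.56 log units; beyond the scatter) and is the larger of the two steps that start from or end at compound 2. The change does more than recover what the carboxy group gave up, since the values show a 3.2-fold lower number from compound 1 to compound 3 (0.50 log units; beyond the scatter) and so put compound 3 clearly past compound 1, making it the most potent of the three compounds on the shared core. Nothing measured here accounts for this order among the three groups, so the reason for it stays unknown.

The compounds shown leave open whether the ethyl itself matters or whether any capping of that oxygen would serve, a question that a methoxy group or a longer chain in its place would address. They also leave open how an amine on the carbonyl carbon, giving an amide in place of the ester, would stand against compound 3 on this read-out.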